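The compounds below may be only part of what the source reports. "The series", "measured", "known", "first", "only" and "open" are said of these compounds alone.

Compound 1, `COc1ccc2c(=O)c(/C=C/C(=O)Nc3ccccc3)coc2c1`, gives 51000 nM in a functional assay on A549 cells (Homo sapiens) for inhibition, read by MTT assay, with a stated time of 48 h; a lower number here means a stronger inhibitor, a higher number a weaker inhibitor.
Compound 2, `COc1ccc2c(=O)c(/C=C/C(=O)NCc3ccc(F)cc3)coc2c1`, reaches in this assay only a limit of the assay, > 100000 nM.
Compound 3, `COc1ccc(CNC(=O)/C=C/c2coc3cc(OC)ccc3c2=O)cc1`, gives 22500 nM in this assay.

Of the two numbers shown, compound 3 holds the lower one; the only other number lies one step away: a 2.3-fold lower number from compound 1 to compound 3 (0.36 log units; beyond the scatter). The third value is a limit and cannot be ranked.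

Compound 4, `COc1ccc2c(=O)c(/C=C/C(=O)Nc3ccc(Cl)cc3)coc2c1`, has not yet been measured in this assay. Its change from compound 3 is 4-chlorophenyl in place of 4-methoxybenzyl on an amide-type nitrogen. Among the measured compounds shown here, two measured steps bear on it. For the measured compounds named here, the first swaps a benzyl-type group for a plain phenyl on the same nitrogen and runs the other way, a 2.3-fold lower number from compound 1 to compound 3 (0.36 log units; beyond the scatter), so reversing it points toward a higher number. The second replaces a halogen by a methoxy group on the ring, an at least 4.4-fold lower number from compound 2 to compound 3 (0.64 log units; beyond the scatter), and also points, in reverse, toward a higher number. Going by the values given here, no compound with chlorine has been measured, so that part of the change is uncharted.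

Compound 4 is therefore expected to show a modest rise, a 2.0-fold higher number from compound 3 to compound 4 (0.30 log units; within the scatter). The estimate for compound 4 is 45000 nM, ranging from 15000 nM to 120000 nM.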

Compound 4, half-maximal inhibitory concentration: > 100000 nM
Compound 4 ended at the assay's limit; the forecaster's own chance of this, stated with the estimate: 25%; at least 2.2-fold (0.34 log units) between middle value and limit.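

Among the compounds shown here, on the amide-type nitrogen, the 4-methoxybenzyl group of compound 3 cannot be exchanged for 4-chlorophenyl without a clear loss in this assay, and this is the largest readable step to a limit from the best compound so far: an at least 4.4-fold higher number from compound 3 to compound 4 (0.64 log units; beyond the scatter). Placing chloro in place of hydrogen on the aromatic ring of compound 1 gives the first view of chlorine in this series, but the floor of this step lies within the scatter, so a real change is not shown: an at least 1.9-fold higher number from compound 1 to compound 4 (0.29 log units; that floor lies within the scatter). The step between compound 2 and compound 4 cannot be read because both sit at a limit: the limit of > 100000 nM in this assay, at which 2 of the 4 values shown sit.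

Compound 3 differs from compound 4 in both the benzyl-type link and the ring substituent, so their separate contributions remain unresolved. From the compounds shown here alone, whether 4-chlorobenzyl or 4-methoxyphenyl on this nitrogen would separate them remains open, as does the outcome with a ring amine such as dimethylamino.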